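Notes on the step from compound 3 to compound 4

The compounds below may be only part of what the source reports. "The series", "measured", "known", "first", "only" and "open" are said of these compounds alone.

compound 1 `CC(C)(C)c1ccc(C(=O)/C=C/c2ccc([N+](=O)[O-])o2)cc1`: > 100000 nM (a limit)
compound 2 `CSc1ccc(C(=O)/C=C/c2ccc([N+](=O)[O-])o2)cc1`: 40700 nM
compound 3 `O=C(/C=C/c1ccc([N+](=O)[O-])o1)c1ccc(N2CCCCC2)cc1`: 349000 nM

Of the two actual numbers in an ADME assay on Vero cells (Chlorocebus sabaeus) for cytotoxicity, read by resazurin assay, with a stated time of 72 h (a lower number here means that less compound is tolerated, a higher number that more compound is tolerated), compound 3 has the higher, 349000 nM. Compound 4 `O=C(/C=C/c1ccc([N+](=O)[O-])o1)c1ccc(Br)cc1` has bromo in place of piperidin-1-yl on an aromatic carbon. The measured changes at this place are an at least 2.4-fold lower number from compound 1 to compound 2 (0.39 log units; beyond the scatter), an 8.6-fold higher number from compound 2 to compound 3 (0.93 log units; beyond the scatter) and a step that the limit leaves unreadable from compound 1 to compound 3. Going by the values given here, the second is the only full-sized reading that involves piperidin-1-yl, so a lower number of similar size is expected on leaving compound 3. The estimated change is a 7.0-fold lower number from compound 3 to compound 4 (0.84 log units; beyond the scatter). For compound 4 the expected value is 50000 nM, with an estimated range of 15000 nM to 150000 nM.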

Compound 4, half-maximal cytotoxic concentration: > 100000 nM
Compound 4 ended at the assay's limit; the forecaster's own chance of this, stated with the estimate: 15%; at least 2.0-fold (0.30 log units) between middle value and limit.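

In this assay compound 4 gives > 100000 nM, which is a limit of the assay and not a number. Bromo in place of methylsulfanyl gives an at least 2.4-fold higher number from compound 2 to compound 4 (0.39 log units; beyond the scatter), so a single bromine atom at this place does not bring the lower number seen with compound 2. The steps to compound 4 from compound 3 and compound 1 cannot be read because of this limit: the limit of > 100000 nM in this assay, at which 2 of the 4 values shown sit.

As far as these compounds go, how compound 1 and compound 4 stand against compound 3 remains open. Also open, from the compounds shown here alone, is where a carboxylic acid, a primary amine or a longer alkyl chain at this place would fall.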